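This account rests on a few compounds, and the source may have more. Where it says the series, first, only, none or still open, it means among the compounds named here.

Working notes on the series. Compound 1 `O=C(CN1CCN(c2nnc(Cc3ccncc3)c3ccccc23)CC1)Nc1ccc(F)c(Cl)c1` gives 880 nM in a functional assay on HT-29 cells (Homo sapiens) for cytotoxicity, read by MTT assay, with a stated time of 72 h; a lower number here means a stronger inhibitor, a higher number a weaker inhibitor. Compound 2 `Cc1ccc(NC(=O)CN2CCN(c3nnc(Cc4ccccc4)c4ccccc34)CC2)c(C)c1` is reported in this assay only as "not active" (no number reported), so no single number places it. Compound 3 `O=C(CN1CCN(c2nnc(Cc3ccccc3)c3ccccc23)CC1)Nc1ccc(F)c(Cl)c1` is not yet tested; against compound 2 it carries 3-chloro-4-fluorophenyl in place of 2,4-dimethylphenyl on an amide-type nitrogen. Compound 1 holds the same 3-chloro-4-fluorophenyl on the amide-type nitrogen and gives 880 nM, so a step toward stronger inhibition in this assay is expected for compound 3, of a size that one inactive entry cannot fix. Compound 3 is estimated at 1500 nM, within 400 nM to 8000 nM.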

Compound 3, half-maximal inhibitory concentration: 13300 nM
The estimate for compound 3 lay 8.9-fold (0.95 log units) below the measured number, and the stated range ends below it.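

Among the compounds shown here, with the 3-chloro-4-fluorophenyl on the amide-type nitrogen held constant, phenyl in place of pyridin-4-yl gives a 15-fold higher number from compound 1 to compound 3 (1.18 log units; beyond the scatter) in this assay, the first readable step at this position. The 3-chloro-4-fluorophenyl group therefore does not by itself secure the number of compound 1, and the pyridin-4-yl group matters in this pair. Nothing at hand explains the step.

Open, going by these compounds, is whether pyridin-3-yl or pyridin-2-yl at this place would behave like pyridin-4-yl or like phenyl. Also open, on these data alone, is how pyridin-4-yl would read alongside 2,4-dimethylphenyl on the amide-type nitrogen.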